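Dimethylamino in Place of Acetyl: an Untested Analogue

The source may hold more compounds than are shown below. What is called first, only, known or untested is meant among the compounds shown, and "the series" means these compounds.

Measured compounds:
compound 1 `Cn1ccc2cc(-c3cc4nccc(-c5ccc(F)cc5)n4n3)ccc21`, 5210 nM
compound 2 `COc1cc(-c2ccnc3cc(-c4ccc(C(C)=O)cc4)nn23)cc(OC)c1OC`, 1810 nM
compound 3 `Cc1ccc(-c2cc3nccc(-c4ccc(F)cc4)n3n2)cc1`, > 10000 nM

In a functional assay on HeLa cells (Homo sapiens) for inhibition, read by CCK-8 assay, with a stated time of 48 h (on this read-out higher numbers stand for weaker inhibition and lower numbers for stronger inhibition), compound 1 gives 5210 nM and compound 2 gives 1810 nM, the lowest of the two numbers shown. Compound 3 sits at > 10000 nM, which is a limit of this assay rather than a number (the limit of > 10000 nM in this assay, at which 1 of the 3 values shown sits).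

Compound 4 `COc1cc(-c2ccnc3cc(-c4ccc(N(C)C)cc4)nn23)cc(OC)c1OC` has not yet been tested. It differs from compound 2 in one place:
dimethylamino in place of acetyl on an aromatic carbon
Going by the values given here, no measured pair shows this change, so its effect is unknown. For compound 4 the expected step is a 1.1-fold higher number from compound 2 to compound 4 (0.04 log units; within the scatter), not beyond the usual scatter. Compound 4 is estimated at 2000 nM, between 600 nM and 6500 nM.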

Compound 4, half-maximal inhibitory concentration: 378 nM
Compound 4: the middle estimate sits 5.3-fold (0.72 log units) above what was measured; measured number outside the range, below it.
By their numbers in this assay, from the lowest: compound 4; then compound 2; then compound 1. At a limit, above all of these: compound 3.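

In this assay the change from 4-acetylphenyl to 4-(dimethylamino)phenyl gives a 4.8-fold lower number from compound 2 to compound 4 (0.68 log units; beyond the scatter) on an otherwise unchanged compound. This shows that the group on this aromatic carbon, para to a large group, matters for the read-out, even though both groups have the same count of heavy atoms and hydrogen-bond acceptors. Nothing measured here explains the size of this step.

Open, on these data alone, is how a primary amine or a carboxylic acid at this place would compare. Also open, as far as these compounds go, is whether this step would carry over to compound 1 or compound 3, which differ from compound 4 in more than one place.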